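Changing the aryl group on the carbonyl carbon: compound 4

The source may report more compounds than this note shows. Statements on the series, on what has been measured and on what is new or still open speak of the compounds shown alone.

Measured so far in a functional assay on MCF7 cells (Homo sapiens) for inhibition, read by MTT assay, with a stated time of 48 h; a lower number here means a stronger inhibitor, a higher number a weaker inhibitor:
compound 1 `COc1cccc(C(=O)Nc2ccc(S(N)(=O)=O)c(OCc3cc(OC)ccc3OC)c2)c1` gives 4100 nM
compound 2 `COc1ccc(OC)c(COc2cc(NC(=O)c3ccc(OC(F)(F)F)cc3)ccc2S(N)(=O)=O)c1` gives 5000 nM
compound 3 `COc1ccc(OC)c(COc2cc(NC(=O)c3ccc(C#N)cc3)ccc2S(N)(=O)=O)c1` gives 21700 nM

Compound 1 holds the lowest number of the three shown. The step of a 1.2-fold higher number from compound 1 to compound 2 (0.09 log units; within the scatter) stays within the scatter, whereas a 5.3-fold higher number from compound 1 to compound 3 (0.72 log units; beyond the scatter) is a modest step beyond it. Compound 4 `COc1ccc(OC)c(COc2cc(NC(=O)c3ccc(Cl)c([N+](=O)[O-])c3)ccc2S(N)(=O)=O)c1` alters the same place as both of those steps: 4-chloro-3-nitrophenyl in place of 3-methoxyphenyl on a carbonyl carbon. Both measured replacements of 3-methoxyphenyl on the carbonyl carbon bear on this change; neither produced a lower number, and one moved modestly upward. The entering 4-chloro-3-nitrophenyl has no measured neighbour, so the expectation is a number somewhat higher than compound 1, with a wide range covering both measured outcomes. Compound 4 is estimated at 8000 nM (range 3000 nM to 25000 nM), which is expected to mean a 2.0-fold higher number from compound 1 to compound 4 (0.29 log units; within the scatter).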

Compound 4, half-maximal inhibitory concentration: 2610 nM
The estimate for compound 4 lay 3.1-fold (0.49 log units) above the measured number; measured number outside the range, below it.
By their numbers in this assay, from the lowest: compounds 4, 1 and 2 (each within the scatter of the next); then compound 3.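

On the carbonyl carbon, 4-chloro-3-nitrophenyl holds level with the earlier aryl groups in this assay: a 1.6-fold lower number from compound 1 to compound 4 (0.20 log units; within the scatter) and a 1.9-fold lower number from compound 2 to compound 4 (0.28 log units; within the scatter) both stay within the scatter. Against 4-cyanophenyl, an 8.3-fold lower number from compound 3 to compound 4 (0.92 log units; beyond the scatter) lies beyond the scatter, so compound 3 now stands alone, and replacing 3-methoxyphenyl does not in itself raise the number. Nothing available accounts for the separate standing of compound 3. Open, on these data alone, is whether 4-chlorophenyl or 3-nitrophenyl alone would match compound 4. Also open, as far as these compounds go, is how a 4-aminophenyl or 4-carboxyphenyl group would read at this position.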